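The compounds below may be only part of what the source reports. "The series", "measured", "known", "first", "only" and "open" are said of these compounds alone.

Values in a functional assay on L1210 cells (Mus musculus) for antiproliferative activity, read by cell counting, with a stated time of 2 days; a higher number here means a weaker inhibitor, a lower number a stronger inhibitor:
Compound 1 `COc1cc(C(=O)c2sc(Nc3ccccc3)nc2N)cc(OC)c1OC`: 18 nM
Compound 2 `COc1ccc(C(=O)c2sc(Nc3ccccc3)nc2N)cc1OC`: > 10000 nM, a limit
Compound 3 `COc1cc(C(=O)c2sc(Nc3ccc(F)cc3)nc2N)cc(OC)c1OC`: not yet measured

Among the measured compounds shown here, compound 1 holds the only actual number in this assay. The result for compound 2 is only a limit. Compound 3 carries fluoro in place of hydrogen on an aromatic carbon, fluoro in place of hydrogen on an aromatic carbon, turning phenyl to 4-fluorophenyl. For the measured compounds named here, the sole measured step, an at least 550-fold higher number from compound 1 to compound 2 (2.74 log units; beyond the scatter), is large, but it concerns a methoxy group, not the phenyl that changes here, so it bears only weakly on this change. A small step is therefore expected, possibly none beyond the scatter, leaning towards a higher number. The estimated step is a 1.7-fold higher number from compound 1 to compound 3 (0.22 log units; within the scatter). For compound 3 the expected value is 30 nM, with an estimated range of 10 nM to 120 nM.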

Compound 3, half-maximal inhibitory concentration: 900 nM
Compound 3: middle estimate off by 30-fold (1.48 log units), on the low side; the measured number lies above the stated range.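

In this assay, fluoro in place of hydrogen, para to a large group on the phenyl, gives a 50-fold higher number from compound 1 to compound 3 (1.70 log units; beyond the scatter). The phenyl is therefore itself sensitive to change, which the earlier step at a methoxy group could not show, and a single fluorine is enough to produce a large step. Nothing measured here accounts for this step. Going by these compounds, it remains open whether the step is particular to fluoro or would also follow from chloro, methyl or methoxy in the same place. On these data alone, whether fluoro elsewhere on the phenyl gives a similar step is also open.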